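From compound 2 to compound 3: chloro for methoxy

The source may hold more compounds than are shown below. What is called first, only, known or untested is meant among the compounds shown, and "the series" means these compounds.

Of the compounds shown here, two have been tested so far, compound 1 (`CCOC(=O)c1c(-c2cccc(-c3ccccc3)c2)[nH]c2cc(Cl)ccc2c1=O`) and compound 2 (`CCOC(=O)c1c(-c2cccc(-c3ccccc3)c2)[nH]c2cc(OC)c(OC)cc2c1=O`). In an ADME assay on Raji cells (Homo sapiens) for cytotoxicity, read by luminescence, with a stated time of 72 h (a lower number here means that less compound is needed, a higher number that more compound is needed for the effect), compound 1 gives > 21500 nM, which is a limit and not a number. Compound 2 gives > 21500 nM, also a limit and not a number. Going by the values given here, compound 2 therefore stands at the limit of > 21500 nM in this assay, at which 2 of the 2 values shown sit, and no measured step is available.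

Compound 3 (`CCOC(=O)c1c(-c2cccc(-c3ccccc3)c2)[nH]c2cc(Cl)c(OC)cc2c1=O`) follows from compound 2 with chloro in place of methoxy on an aromatic carbon, ortho to a methoxy group: chloro in place of methoxy on an aromatic carbon.

No step beyond the scatter is expected in this assay, so no direction is assigned. The expected change is a step that the limit leaves unreadable from compound 2 to compound 3. A further limit is the most likely report. For compound 3 the estimated value is 22000 nM, with an expected range of 9000 nM to 45000 nM.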

Compound 3, half-maximal effective concentration: > 21500 nM
Compound 3: a limit, no number; the forecaster's own chance of this, stated with the estimate: 80%; the middle value does not contradict the limit.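

No new step can be read among compound 1, compound 2 and compound 3 in this assay; each gives a limit and not a number: the limit of > 21500 nM in this assay, at which 3 of the 3 values shown sit. The compounds shown leave open whether any change on the shared core alters the read-out.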